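The source may report more compounds than this note shows. Statements on the series, on what has been measured and on what is new or still open speak of the compounds shown alone.

Compound 1 `Nc1scc(-c2ccc([N+](=O)[O-])cc2)c1C(=O)c1ccccc1` gives 47% in a functional assay on CHO cells for agonist activity at adenosine receptor A1 (Homo sapiens), read by fluorescence and ERK phosphorylation, with stated times of 30 min and 1.5 h, tested at 10 uM; a lower number here means a weaker effect, a higher number a stronger effect of the compound at the concentration tested. Compound 2 `COc1ccc(-c2csc(N)c2C(=O)c2ccccc2)cc1` carries methoxy in place of nitro on an aromatic carbon; in this assay compound 2 gives 52%, and the step is a number 5 percentage points higher from compound 1 to compound 2 (within the scatter). Compound 3 `Nc1scc(-c2ccc([N+](=O)[O-])cc2)c1C(=O)c1ccc(Cl)cc1` differs from compound 1 by chloro in place of hydrogen on an aromatic carbon, and in this assay compound 3 gives 52%, a step of a number 5 percentage points higher from compound 1 to compound 3 (within the scatter). Compound 3 and compound 2 stand level at the digits given, and together they hold the two highest numbers among the three, though none of the three is set apart from the others beyond the scatter.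

Compound 4 `COc1ccc(-c2csc(N)c2C(=O)c2ccc(Cl)cc2)cc1` has not yet been measured. It differs from compound 3 by methoxy in place of nitro on an aromatic carbon, the same change that turned compound 1 into compound 2, where it made a step of a number 5 percentage points higher from compound 1 to compound 2 (within the scatter). The two cores on which the change is made differ by chloro in place of hydrogen on an aromatic carbon. Because that earlier step a number 5 percentage points higher from compound 1 to compound 2 (within the scatter) lay within the scatter, the expected step is a number 3 percentage points higher from compound 3 to compound 4 (within the scatter). Compound 4 is thus estimated at 55% in this assay, with a range from 40% to 70%.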

Compound 4, a percentage reported as activity, at one concentration (the size of the read-out at that concentration, not a potency): 55%
The estimate for compound 4 equals the measured number at the digits printed; low and high end bracket the measured number.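

Methoxy in place of nitro gives a number 3 percentage points higher from compound 3 to compound 4 (within the scatter) in this assay, and this step agrees with the one made on the other core: the same change on two cores in this assay, a number 5 percentage points higher (within the scatter) from compound 1 to compound 2 and a number 3 percentage points higher (within the scatter) from compound 3 to compound 4, 2 percentage points apart, within the scatter of two such steps

Chloro in place of hydrogen gives a number 3 percentage points higher from compound 2 to compound 4 (within the scatter), and this step likewise agrees with its earlier counterpart: the same change on two cores in this assay, a number 5 percentage points higher (within the scatter) from compound 1 to compound 3 and a number 3 percentage points higher (within the scatter) from compound 2 to compound 4, 2 percentage points apart, within the scatter of two such steps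

Neither change therefore reads differently from one core to the other, yet all four steps lie within the scatter, so the series shows no measurable effect of either change that could be said to carry over, only the absence of any visible difference between cores at the one concentration tested.

The compounds shown leave open whether a different group at this place on the six-membered ring, such as a carboxylic acid or a longer chain, would move the read-out beyond the scatter. They also speak only to a stronger or weaker effect at the one concentration tested.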